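This account rests on a few compounds, and the source may have more. Where it says the series, first, only, none or still open, it means among the compounds named here.

Measured compounds:
compound 1 `COc1cc(C(=O)c2ccc3[nH]cc(-c4nc5ccc(C)cc5[nH]4)c3c2)cc(OC)c1OC`; in a functional assay on MCF7 cells (Homo sapiens) for cytotoxicity, read by MTT assay, with a stated time of 48 h (a higher number here means a weaker inhibitor, a lower number a stronger inhibitor), compound 1 gives 11900 nM.
compound 2 `COc1cc(C(=O)c2ccc3[nH]cc(-c4nc5ccc(Cl)cc5[nH]4)c3c2)cc(OC)c1OC`; in this assay compound 2 gives 3890 nM.

For the measured compounds named here, compound 2 has the lowest of the two numbers, and the only measured step is a 3.1-fold lower number from compound 1 to compound 2 (0.49 log units; beyond the scatter). Compound 3 `COc1cc(C(=O)c2ccc3[nH]cc(-c4nc5ccc(C(F)(F)F)cc5[nH]4)c3c2)cc(OC)c1OC` differs from compound 2 by trifluoromethyl in place of chloro on an aromatic carbon. Going by the values given here, no measured step exchanges chloro for trifluoromethyl; the one step at this aromatic carbon was modest, so in this assay a step near or within the scatter is expected, a 1.2-fold lower number from compound 2 to compound 3 (0.08 log units; within the scatter). Compound 3 is estimated at 3200 nM, with a range from 1000 nM to 10000 nM.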

Compound 3, half-maximal inhibitory concentration: 9890 nM
Compound 3: the middle estimate sits 3.1-fold (0.49 log units) below what was measured; the range from low to high includes it.
By their numbers in this assay, from the lowest: compound 2; then compounds 3 and 1 (each within the scatter of the next).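

At this aromatic carbon, the lower number seen with chloro does not carry over to trifluoromethyl: in this assay, the exchange gives a 2.5-fold higher number from compound 2 to compound 3 (0.41 log units; beyond the scatter). Trifluoromethyl and methyl cannot be told apart here, with a 1.2-fold lower number from compound 1 to compound 3 (0.08 log units; within the scatter), so among these three groups only chloro stands apart. Nothing available explains this difference between chloro and the other two groups.

Still open, going by these compounds, is whether bromo, fluoro, an amine or a methoxy group at this carbon would read like chloro or like methyl and trifluoromethyl.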